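The compounds below may be only part of what the source reports. "The series", "measured", "known", "first", "only" and "open" are said of these compounds alone.

Measured so far:
- compound 1 `CCN(C(=O)C1CCN(S(=O)(=O)c2ccc(OC)cc2)CC1)[C@@H](C)c1ccccc1`: "not determined" (no result reported)
- compound 2 `CCN(C(=O)C1CCN(S(=O)(=O)c2ccc3occc3c2)CC1)[C@H](C)c1ccccc1`: 80%
- compound 3 `CCN(Cc1cccc(F)c1)C(=O)C1CCN(S(=O)(=O)c2ccc3cn[nH]c3c2)CC1`: 89%

In a functional assay on CHO cells for positive allosteric modulation of muscarinic acetylcholine receptor M5 (Homo sapiens), read by calcium flux (on this read-out higher numbers stand for larger maximal responses and lower numbers for smaller maximal responses), compound 3 gives 89%, and compound 2 gives 80%; the two numbers lie within the usual scatter of each other, so neither can be called larger. Compound 1 has no value in this assay.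

Compound 4 `CCN(Cc1ccccc1OC)C(=O)C1CCN(S(=O)(=O)c2ccc3cn[nH]c3c2)CC1` differs from compound 3 in one place: 2-methoxyphenyl in place of 3-fluorophenyl on a saturated chain carbon bound to an amide-type nitrogen. Going by the values given here, no measured pair shows what such a change does to the largest response, so there is no basis for expecting a step beyond the scatter in either direction. The step of a number 4 percentage points lower from compound 3 to compound 4 (within the scatter) is therefore expected to stay within the scatter. Compound 4 is expected to give 85%, within a range from 65% to 100%.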

Compound 4, largest response reached (reported as percent of maximum), in percent of the reference or control that the assay uses: 92%
The estimate for compound 4 lay 7 percentage points below the measured number; measured number inside the range.
By their numbers in this assay, from the lowest: compounds 2, 3 and 4 (each within the scatter of the next, the first and the last beyond it).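

In this assay, 2-methoxybenzyl in place of 3-fluorobenzyl gives a number 3 percentage points higher from compound 3 to compound 4 (within the scatter), so at this position, on a saturated chain carbon bound to an amide-type nitrogen, the two groups cannot be told apart by largest response. Going by these compounds alone, this is the first single-place comparison, and it shows that this exchange of ring substituents leaves the read-out within its normal variation. No measurement here accounts for this result. Still open, on these data alone, is whether the response would hold with an amine or a carboxylic acid on this ring, or with a longer chain between ring and nitrogen.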